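A few compounds are considered here, and "the series" means these few. Any claim that something is new, unique, unknown or untested is made for them only; others in the source may bear on it.

Compound 3 `COc1ccc(S(=O)(=O)Nc2nnc(SCc3ccccc3)s2)cc1` was tested in a functional assay on MCF7 cells (Homo sapiens) for cytotoxicity, tested at 125 uM (on this read-out higher numbers stand for a weaker effect at the one concentration tested and lower numbers for a stronger effect), and gives 76%, the lowest of the three numbers yet within the scatter of both others. Compound 1 `O=S(=O)(Nc1nnc(SCc2ccc(Cl)cc2)s1)c1ccccc1` gives 85% in this assay, and compound 2 `Cc1ccc(S(=O)(=O)Nc2nnc(SCc3ccc(Cl)cc3)s2)cc1` gives 82%. Among the compounds with values here, the one measured single-point step, a number 3 percentage points lower from compound 1 to compound 2 (within the scatter), concerns a different group. Compound 4 `COc1ccc(S(=O)(=O)Nc2nnc(SCc3ccc(Cl)cc3)s2)cc1` differs from compound 3 by chloro in place of hydrogen on an aromatic carbon. Within the data shown here, no measured step introduces this group; compounds 1 and 3 differ in two places at once, and their two numbers sit within the scatter of each other. The change is therefore expected to give a number 1 percentage points higher from compound 3 to compound 4 (within the scatter), nothing beyond the scatter. Compound 4 is estimated at 77%, in the range 65% to 89%.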

Compound 4, a percentage reported as activity, at one concentration (the size of the read-out at that concentration, not a potency): 55%
Compound 4: the middle estimate sits 22 percentage points above what was measured; measured number below the stated range.
By their numbers in this assay, from the lowest: compound 4; then compounds 3, 2 and 1 (each within the scatter of the next).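

In this assay the change from benzyl to 4-chlorobenzyl gives a number 21 percentage points lower from compound 3 to compound 4 (beyond the scatter) with the methoxy present, so chloro at this place counts here. With the 4-chlorobenzyl kept, methoxy gives a number 27 percentage points lower from compound 2 to compound 4 (beyond the scatter) in place of methyl and a number 30 percentage points lower from compound 1 to compound 4 (beyond the scatter) in place of hydrogen, so only the compound carrying both groups stands apart, while compounds 1, 2 and 3 lie within the scatter of each other. Nothing available accounts for this result. On these data alone, whether bromo or a nitrile at this place, or an amine in place of the methoxy, would give a similar step stays open.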